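This account rests on a few compounds, and the source may have more. Where it says the series, first, only, none or still open, it means among the compounds named here.

Measured compounds:
Compound 1 `CCOc1ccc(/C=N/n2c(S)nnc2-c2cnccn2)cc1OC` — in a functional assay, with a stated time of 30 min (a lower number here means a stronger inhibitor, a higher number a weaker inhibitor), compound 1 gives 58800 nM.
Compound 2 `Fc1cccc(NC(=S)Nn2c(S)nnc2-c2cnccn2)c1` — in this assay compound 2 gives 14000 nM.

Compound 2 has the lower of the two numbers. The number for compound 1 is higher, and the gap between compound 2 and compound 1 lies beyond the usual scatter of repeated measurements, so compound 2 is the stronger inhibitor of the two in this assay. Compound 3 `S=C(Nc1ccc(Cl)c(Cl)c1)Nn1c(S)nnc1-c1cnccn1` has not yet been measured. It differs from compound 2 in one place: 3,4-dichlorophenyl in place of 3-fluorophenyl on an amide-type nitrogen. Among the compounds with values here, no step between two measured compounds that differ in a single place is available here, so there is nothing to show how large a change of this kind tends to be. Without any comparable pair to lean on, the expectation is that compound 3 stays close to compound 2, with no step beyond the scatter in either direction, though a move of this sort could plausibly go either way. The step in this assay that this estimate means is a 1.4-fold lower number from compound 2 to compound 3 (0.15 log units; within the scatter). For compound 3 the expected value in this assay is 10000 nM, within a range from 3000 nM to 40000 nM.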

Compound 3, half-maximal inhibitory concentration: 81200 nM
Beside the measured number, compound 3's estimate is 8.1-fold (0.91 log units) below it; measured number outside the range, above it.
By their numbers in this assay, from the lowest: compound 2; then compounds 1 and 3 (each within the scatter of the next).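

Within the data shown here, this is the first pair here that differs in one place only, so it gives the first direct reading of the aromatic group on the amide-type nitrogen whose other neighbour is the thiocarbonyl carbon: in this assay, putting 3,4-dichlorophenyl in place of 3-fluorophenyl gives a 5.8-fold higher number from compound 2 to compound 3 (0.76 log units; beyond the scatter). The position is therefore not indifferent to what its phenyl ring carries, and of these two groups the 3-fluorophenyl of compound 2 gives the stronger inhibitor, though a single step cannot show a general trend. No supporting data accompany this step, so the measurements give no explanation for it.

The change removes one fluorine and brings in two chlorines, so the compounds shown cannot tell whether the step follows from losing the fluorine, from gaining chlorine, or from both together. On these data alone, how a plain phenyl group, a benzyl group or a methoxyphenyl group would behave at this nitrogen remains open, as does whether any group here could give a lower number than compound 2 at 14000 nM.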